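This account rests on a few compounds, and the source may have more. Where it says the series, first, only, none or still open, it means among the compounds named here.

Of the compounds shown here, two have been measured in a functional assay on cells for antagonist activity at C-X-C chemokine receptor type 4 (Homo sapiens), read by fluorescence and calcium flux, with stated times of 25 min and 90 s; on this read-out lower numbers stand for stronger inhibition and higher numbers for weaker inhibition. Compound 1 `c1ccc2c(c1)CN[C@@H](CN(CCCCNC1CCOCC1)[C@H]1CCCc3cccnc31)C2` gives 29.4 nM, and compound 2 `CC(C)(N)CCCN(C[C@H]1Cc2ccccc2CN1)[C@H]1CCCc2cccnc21` gives 24.6 nM. Going by the values given here, the only measured step, a 1.2-fold lower number from compound 1 to compound 2 (0.08 log units; within the scatter), puts 1-amino-1-methylethyl in place of ((oxan-4-yl)amino)methyl on a saturated chain carbon, three bonds along the chain from an amine nitrogen. On these numbers compound 2 stands at the lower of the two values, with compound 1 within the scatter of it.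

Compound 3 `CC(C)(CCN(C[C@H]1Cc2ccccc2CN1)[C@H]1CCCc2cccnc21)CNCC1CCOCC1` has not been measured. It differs from compound 2 by a group of 12 heavy atoms (10 carbon, 1 nitrogen, 1 oxygen; one six-membered non-aromatic ring with 1 hetero atom) in place of a group of 5 heavy atoms (4 carbon, 1 nitrogen; no ring), on a saturated chain carbon, two bonds along the chain from an amine nitrogen. This change brings back a six-membered ring with one oxygen of the kind present in compound 1 while keeping the two methyl groups of compound 2. Since the step from compound 1 to compound 2 stayed within the scatter, the expected step of a 1.1-fold higher number from compound 2 to compound 3 (0.06 log units; within the scatter) is likewise small. Compound 3 is therefore estimated at 28 nM, in a range from 10 nM to 80 nM.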

Compound 3, half-maximal inhibitory concentration: 43.8 nM
For compound 3 the middle estimate is 1.6-fold (0.19 log units) below the measured one; measured number inside the range.
By their numbers in this assay, from the lowest: compounds 2, 1 and 3 (each within the scatter of the next).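

This chain position accepts a much larger group than 2-amino-2-methylpropyl without leaving the scatter in this assay: swapping in the group with a six-membered non-aromatic ring gives a 1.8-fold higher number from compound 2 to compound 3 (0.25 log units; within the scatter). The two side chains carrying such a ring also stay together, with a 1.5-fold higher number from compound 1 to compound 3 (0.17 log units; within the scatter), so none of the three side chains separates from the others on these numbers. Nothing measured here offers an explanation for this flat result.

On these data alone, all three side chains carry an amine, so it remains open whether a carboxylic acid or a hydroxyl group could take that amine's place. As far as these compounds go, it is equally open whether a phenyl ring in place of the oxygen-containing ring, or a longer chain, would move the number beyond the scatter.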